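Hydrazone series: cytotoxicity after removal of the hydroxy

The source may report more compounds than this note shows. Statements on the series, on what has been measured and on what is new or still open speak of the compounds shown alone.

Of the compounds shown here, two have been tested in an ADME assay on cells (Mus musculus, strain BALB/C) for cytotoxicity, read by MTT assay, with a stated time of 24 h; a lower number here means that less compound is tolerated, a higher number that more compound is tolerated. Compound 1 `Cc1ccc(C(=O)N/N=C/c2cccc(Cl)c2)c(O)c1` gives 636000 nM in this assay. Among the measured compounds shown here, compound 2 `Cc1ccc(C(=O)N/N=C/c2cc(Br)ccc2O)c(O)c1` gives 1500000 nM in this assay and stands highest of the two numbers measured so far; its nearest neighbour is compound 1, whose number is lower by a gap that lies beyond the usual scatter. For the measured compounds named here, no step between measured compounds that differ in a single place has been recorded, so nothing is yet known about how any one change moves this read-out.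

Compound 3 `Cc1ccc(C(=O)N/N=C/c2cccc(Br)c2)c(O)c1` is the next compound for this assay. Relative to compound 2 it carries hydrogen in place of hydroxy on an aromatic carbon. Going by the values given here, with no measured single-site step available, the direction of this change can only be guessed from the spread of the two numbers on hand, which suggests a downward step of modest size, possibly beyond the scatter. Compound 3 is expected to give about 700000 nM in this assay, with a plausible range from 300000 nM to 1600000 nM. The expected step is a 2.1-fold lower number from compound 2 to compound 3 (0.33 log units; beyond the scatter).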

Compound 3, half-maximal cytotoxic concentration: 113000 nM
Beside the measured number, compound 3's estimate is 6.2-fold (0.79 log units) above it, and the stated range ends above it.
By their numbers in this assay, from the lowest: compound 3; then compound 1; then compound 2.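

Notes on the series: in this assay, the hydroxy on the aromatic carbon ortho to a large group and para to a bromo group proves to matter, since hydrogen in its place gives a 13-fold lower number from compound 2 to compound 3 (1.12 log units; beyond the scatter). The halogen site responds as well: bromo in place of chloro on an aromatic carbon gives a 5.6-fold lower number from compound 1 to compound 3 (0.75 log units; beyond the scatter), so less of compound 3 is tolerated in both comparisons. Among the compounds shown here, both steps lie beyond the scatter and the hydroxy step is the larger, but these are the first single-site steps and each rests on one pair only.

No supporting data bear on why either change lowers the number. Still open, as far as these compounds go, is whether a methoxy group or an amine on that same aromatic carbon would keep the higher number of compound 2 or fall towards compound 3, and whether the step from chloro to bromo would hold in the presence of the hydroxy.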